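The compounds below may be only part of what the source reports. "The series", "measured", "known", "first", "only" and "open" are said of these compounds alone.

Measured so far in an assay on CHO cells for displacement of a labelled ligand from Substance-K receptor (Homo sapiens); on this read-out higher numbers stand for weaker inhibition and lower numbers for stronger inhibition:
compound 1 `CCOC(=O)C1=C(C)OC2OC(COCc3ccccc3)C(OCc3ccccc3)C(OCc3ccccc3)C2S1` gives 12600 nM
compound 2 `CCOC(=O)C1=C(C)OC2OC(COCc3ccccc3)C(OCc3ccccc3)C(O)C2S1` gives 12600 nM
compound 3 `CCOC(=O)C1=C(C)OC2OC(CO)C(OCc3ccccc3)C(OCc3ccccc3)C2S1` gives 4000 nM

Compound 3 stands lowest of the three in this assay: a 3.2-fold lower number from compound 1 to compound 3 (0.50 log units; beyond the scatter), while compounds 1 and 2 sit together within the scatter. Compound 4 `CCOC(=O)C1=C(C)OC2OC(CO)C(OCc3ccccc3)C(O)C2S1` differs from compound 3 in one place: hydrogen in place of benzyl on an oxygen on a saturated carbon. For the measured compounds named here, the oxygen concerned is the same one freed in the only direct precedent, which gave no change at the digits printed from compound 1 to compound 2 (within the scatter). The other debenzylation, a 3.2-fold lower number from compound 1 to compound 3 (0.50 log units; beyond the scatter), is already built into compound 3 and does not bear on this oxygen. With one precedent showing no movement, compound 4 is expected to show no change at the digits printed from compound 3 to compound 4 (within the scatter). Compound 4 is therefore estimated at 4000 nM, within a range of 1600 nM to 10000 nM.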

Compound 4, inhibition constant: > 10000 nM
Compound 4 gave a limit, no number (the forecaster's own chance of this, stated with the estimate: 5%); at least 2.5-fold (0.39 log units) between middle value and limit.
By their numbers in this assay, from the lowest: compound 3; then compounds 1 and 2 (each within the scatter of the next).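

In this assay, the change from benzyloxy to hydroxy on this saturated carbon does not leave the number unmoved on every core: an at least 2.5-fold higher number from compound 3 to compound 4 (0.39 log units; beyond the scatter). Compound 4 reads > 10000 nM, which is a limit of the assay and not a number. Whether the outcome of this change depends on the rest of the molecule remains unsettled: the same change on two cores in this assay, no change at the digits printed (within the scatter) from compound 1 to compound 2 and an at least 2.5-fold higher number (0.39 log units; beyond the scatter) from compound 3 to compound 4; the limit leaves it open whether they differ

The step from compound 2 to compound 4 cannot be read. Also open, from the compounds shown here alone, is whether an amine or a carboxylic acid in place of the benzyloxy on this saturated carbon would give a lower number than hydroxy does.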